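Urea nitrogen swap in the anilinoquinazoline urea series

The compounds below may be only part of what the source reports. "The series", "measured", "known", "first", "only" and "open" are said of these compounds alone.

Among the compounds with values here, compound 2 `CCN(CC)c1ccc(NC(=O)Nc2ccc3ncnc(Nc4cccc(C(F)(F)F)c4)c3c2)cc1` gives 6460 nM in a functional assay on A-431 cells (Homo sapiens) for antiproliferative activity, read by MTT assay, with a stated time of 72 h (on this read-out higher numbers stand for weaker inhibition and lower numbers for stronger inhibition), and this is the only number in the set so far. Compound 1 `O=C(Nc1ccccc1)Nc1ccc2ncnc(Nc3cccc(C(F)(F)F)c3)c2c1` returns a limit, > 10000 nM, not a number; that is the limit of > 10000 nM in this assay, at which 1 of the 2 values shown sits. Within the data shown here, the single measured step, an at least 1.5-fold lower number from compound 1 to compound 2 (0.18 log units; that floor lies within the scatter), therefore has only a floor and says little about the direction that a substituent on the phenyl of the urea sets.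

Compound 3 `CN1CCN(CCNC(=O)Nc2ccc3ncnc(Nc4cccc(C(F)(F)F)c4)c3c2)CC1` takes the step 2-(4-methylpiperazin-1-yl)ethyl in place of 4-(diethylamino)phenyl on an amide-type nitrogen: the whole aryl group leaves and a two-carbon chain carrying a methylpiperazine enters on the amide-type nitrogen. Among the measured compounds shown here, no measured step covers such a swap; the step from compound 1 to compound 2 alters only a substituent on the phenyl that now leaves, so it gives no direct guide. The expectation is thus wide. Compound 3 is expected to sit at about the level of compound 2, with a modest drift toward a weaker number and a real chance of landing at the limit, so that the estimated step is a 1.4-fold higher number from compound 2 to compound 3 (0.14 log units; within the scatter). The estimate for compound 3 in this assay is 9000 nM, between 3000 nM and 30000 nM.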

Compound 3, half-maximal inhibitory concentration: > 10000 nM
Compound 3 ended at the assay's limit; the forecaster's own chance of this, stated with the estimate: 45%; middle value at least 1.1-fold (0.04 log units) from the limit.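

In this assay, the swap on the amide-type nitrogen gives an at least 1.5-fold higher number from compound 2 to compound 3 (0.18 log units; that floor lies within the scatter), so only a floor is available, and it does not establish that 2-(4-methylpiperazin-1-yl)ethyl is poorer than 4-(diethylamino)phenyl at this place. Of the three groups on this nitrogen, only 4-(diethylamino)phenyl yields a number rather than a limit, though this describes these three compounds and is not a trend. Compound 1 and compound 3 both rest at the same limit, so the step between them cannot be read, and compound 2 remains the only number from which any comparison can start: the limit of > 10000 nM in this assay, at which 2 of the 3 values shown sit.

As far as these compounds go, it remains open whether the number for compound 2 depends on the aromatic ring, on the diethylamino group or on both, and a 2-(diethylamino)ethyl chain or a 4-(4-methylpiperazin-1-yl)phenyl group on the same amide-type nitrogen would separate these. From the compounds shown here alone, how far compound 1 and compound 3 lie past the limit also stays unknown, so the size of any loss on leaving 4-(diethylamino)phenyl is undefined.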